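Compound 4 Opens the Ring of Compound 3

The source may report more compounds than this note shows. Statements on the series, on what has been measured and on what is new or still open speak of the compounds shown alone.

Compound 1 `CC(C)c1nc2c(C(=O)NCC3CCN(CCN4CCN(S(C)(=O)=O)CC4)CC3)cccc2[nH]1` gives > 1.5 h (a limit)
Compound 2 `COC(=O)N1CCN(CCN2CCC(CNC(=O)c3cccc4[nH]c(C(C)C)nc34)CC2)CC1` gives > 1.5 h (a limit)
Compound 3 `CC(=O)N1CCN(CCN2CCC(CNC(=O)c3cccc4[nH]c(C(C)C)nc34)CC2)CC1` gives > 1.5 h (a limit)

In an ADME assay on microsomes from liver (Rattus norvegicus) for metabolic stability (a lower number here means that the compound disappears faster, a higher number that the compound lasts longer), compound 3 gives > 1.5 h as a limit of the assay, not a number. Compound 3 therefore has no exact place among the others, as the limit of > 1.5 h in this assay, at which 3 of the 3 values shown sit, makes plain.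

Compound 4 `COC(=O)N(C)CC(O)CN1CCC(CNC(=O)c2cccc3[nH]c(C(C)C)nc23)CC1` has not yet been measured. The change 1-hydroxy-2-((methoxycarbonyl)(methyl)amino)ethyl in place of (4-acetylpiperazin-1-yl)methyl on a saturated chain carbon bound to an amine nitrogen in a ring puts 1-hydroxy-2-((methoxycarbonyl)(methyl)amino)ethyl in place of (4-acetylpiperazin-1-yl)methyl, so the entering group has no ring.

Within the data shown here, three measured steps bear on this: a step that the two limits leave unreadable from compound 1 to compound 2 and a step that the two limits leave unreadable from compound 1 to compound 3 and a step that the two limits leave unreadable from compound 2 to compound 3 all leave their size unknown. They involve smaller swaps, and no size can be carried over from them. The expected change, a step that the limit leaves unreadable from compound 3 to compound 4 in this estimate, is nothing beyond the scatter in either direction. For compound 4 the estimated half-life in this assay is 1.6 h (expected range 0.8 h to 3 h).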

Compound 4, half-life: 1.32 h
The estimate for compound 4 lay 1.2-fold (0.08 log units) above the measured number, and the stated range covers the measured number.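

Among these compounds, compound 4 is the first compound here to give a number rather than a limit in this assay, so a group with no ring, 2-hydroxy-3-((methoxycarbonyl)(methyl)amino)propyl, now has a readable value at this place. The comparison with the three piperazine compounds gives an at least 1.1-fold lower number from compound 3 to compound 4 (0.05 log units; that floor lies within the scatter), an at least 1.1-fold lower number from compound 2 to compound 4 (0.05 log units; that floor lies within the scatter) and an at least 1.1-fold lower number from compound 1 to compound 4 (0.05 log units; that floor lies within the scatter), so opening the ring shows no loss beyond the scatter, though each step is only a floor. The steps among compound 1, compound 2 and compound 3 cannot be read, since all three sit at one limit: the limit of > 1.5 h in this assay, at which 3 of the 4 values shown sit.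

Going by these compounds, how far the true half-lives of those three compounds lie from compound 4 stays open, and with it the real size of all three steps. The compounds shown also leave open what the hydroxy group adds, which the same chain without it, or a chain ending in an amine, could help to separate.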